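Replacing the amino-bearing group of compound 3 with phenyl

A few compounds are considered here, and "the series" means these few. Any claim that something is new, unique, unknown or untested is made for them only; others in the source may bear on it.

In a physicochemical assay for lipophilicity, read by HPLC, measured as chromatographic lipophilicity, at pH 7.4 (a lower number here means a more polar compound, a higher number a more lipophilic compound), compound 1 (`O=C(C1CCOC1)N1N=CCC1c1ccccc1`) gives 3 and compound 2 (`CC(C)(CO)C(=O)N1N=CCC1c1ccccc1`) gives 3.4 while compound 3 (`CC(C)(CN)C(=O)N1N=CCC1c1ccccc1`) gives 1.4 and so stands lowest of the three. Compound 1 is its nearest neighbour on these numbers and compound 2 its furthest.

The next compound is compound 4 (`O=C(c1ccccc1)N1N=CCC1c1ccccc1`) with phenyl in place of 1-(aminomethyl)-1-methylethyl on a carbonyl carbon. Going by the values given here, no measured step has phenyl entering, so the expectation rests on related changes. Amino in place of hydroxy gave a number 2.00 log units lower from compound 2 to compound 3 (beyond the scatter) and 1-(aminomethyl)-1-methylethyl in place of oxolan-3-yl gave a number 1.60 log units lower from compound 1 to compound 3 (beyond the scatter) while the two compounds without amino differ by only a number 0.40 log units higher from compound 1 to compound 2 (beyond the scatter) as a modest step. Compound 4 also carries no amino, as is true of compound 1 (3) and compound 2 (3.4), so it is expected to land near them or somewhat higher. The expected change is large and upward (a number 2.40 log units higher from compound 3 to compound 4 (beyond the scatter)). The estimate for compound 4 is 3.8 (expected range 3.2 to 4.4).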

Compound 4, distribution coefficient: 4.6
The estimate for compound 4 lay 0.80 log units below the measured number; measured number above the stated range.
By their numbers in this assay, from the lowest: compound 3; then compound 1; then compound 2; then compound 4.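

At the carbonyl carbon whose other neighbours are the amide-type nitrogen in a ring, phenyl gives the highest number of the four compounds in this assay, well clear of the group bearing the amino (a number 3.20 log units higher from compound 3 to compound 4 (beyond the scatter)). Leaving out the amino is therefore not what sets the upper end of the range at this position, since phenyl also stands well above the two groups that have no amino, the one bearing hydroxy (a number 1.20 log units higher from compound 2 to compound 4 (beyond the scatter)) and oxolan-3-yl (a number 1.60 log units higher from compound 1 to compound 4 (beyond the scatter)). No measurement offered here accounts for the size of these steps.

Because phenyl differs from each earlier group in several ways at once, as an aromatic ring of carbon only with neither hydrogen-bond donors nor acceptors, these compounds cannot separate the contribution of the aromatic ring from that of the missing hydroxy, amino or ring oxygen. A cyclohexyl group at the same carbonyl carbon would test the aromatic ring directly, and an amine or a carboxylic acid carried on the phenyl would show how far such a group pulls the number back.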